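The compounds below may be only part of what the source reports. "The series", "measured", "known", "first", "only" and "open" are said of these compounds alone.

Of the compounds shown here, two sharing one core have been measured in a functional assay on DU-145 cells (Homo sapiens) for cytotoxicity, read by trypan blue exclusion, with a stated time of 96 h; on this read-out lower numbers stand for stronger inhibition and higher numbers for weaker inhibition. Compound 1 (`COc1cc(OC)c(/C=C/S(=O)(=O)Nc2ccc(OC)c(OP(=O)(O)O)c2)c(OC)c1`) gives 40 nM. Compound 2 (`COC(=O)C(C)Nc1cc(NS(=O)(=O)/C=C/c2c(OC)cc(OC)cc2OC)ccc1OC`) gives 100 nM, the higher of the two numbers. Within the data shown here, the only measured step is a 2.5-fold higher number from compound 1 to compound 2 (0.40 log units; beyond the scatter), a modest change that exchanges a whole group on an aromatic carbon.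

Compound 3 (`COC(=O)C(C)(C)Nc1cc(NS(=O)(=O)/C=C/c2c(OC)cc(OC)cc2OC)ccc1OC`) departs from compound 2 by methyl in place of hydrogen on a saturated chain carbon bound to a carbonyl carbon, a nitrogen on an aromatic ring and a saturated chain carbon. This places methyl in place of hydrogen on a saturated chain carbon bound to a carbonyl carbon, a nitrogen on an aromatic ring and a saturated chain carbon, so that 1-(methoxycarbonyl)ethyl becomes 1-(methoxycarbonyl)-1-methylethyl. Among the measured compounds shown here, the step to compound 2 bears on this only loosely, as a guide to size: no measured pair tests a methyl on this carbon. The single added methyl is a much smaller edit than that group exchange, so a small shift is expected in this assay. The expected outcome is a 1.5-fold higher number from compound 2 to compound 3 (0.18 log units; within the scatter), leaning towards a higher number. For compound 3 the estimated value is 150 nM, with an expected range from 50 nM to 450 nM.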

Compound 3, half-maximal inhibitory concentration: 200 nM
The estimate for compound 3 lay 1.3-fold (0.12 log units) below the measured number; low and high end bracket the measured number.
By their numbers in this assay, from the lowest: compound 1; then compounds 2 and 3 (each within the scatter of the next).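

In this assay, among these compounds, the step of a 2.0-fold higher number from compound 2 to compound 3 (0.30 log units; within the scatter) gives the first reading at this saturated chain carbon, and it shows that changing 1-(methoxycarbonyl)ethyl to 1-(methoxycarbonyl)-1-methylethyl produces no difference that this read-out can separate from repeat measurement. The larger group still stands apart from the group on the aromatic carbon of compound 1, with a step of a 5.0-fold higher number from compound 1 to compound 3 (0.70 log units; beyond the scatter) that, like the step of a 2.5-fold higher number from compound 1 to compound 2 (0.40 log units; beyond the scatter), lies beyond the scatter, so compound 1 keeps the lowest number of the three. No measurement in hand offers an explanation for either step.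

The compounds shown leave open whether a carboxylic acid in place of the methyl ester, or an ethyl group in place of the added methyl on this carbon, would also stay within the scatter of compound 2. They also leave open how a plain amine on the same aromatic carbon, carrying neither side chain, would stand against compound 1 on this read-out.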